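The source may hold more compounds than are shown below. What is called first, only, known or untested is meant among the compounds shown, and "the series" means these compounds.

Measured so far in a functional assay on MKN-45 cells (Homo sapiens) for cytotoxicity, read by MTT assay, with a stated time of 72 h; on this read-out higher numbers stand for weaker inhibition and lower numbers for stronger inhibition:
compound 1 `Cn1c(=O)c(C(=O)Nc2ccc(Oc3ccncc3-c3cccnc3)c(F)c2)nn(-c2ccc(Cl)cc2)c1=O` gives 1600 nM;
compound 2 `Cn1c(=O)c(C(=O)Nc2ccc(Oc3ccncc3-c3cccnc3)c(F)c2)nn(-c2c(Cl)cccc2Cl)c1=O` gives 3930 nM;
compound 3 `Cn1c(=O)c(C(=O)Nc2ccc(Oc3ccncc3-c3cccnc3)c(F)c2)nn(-c2ccc(F)c(Cl)c2)c1=O` gives 10100 nM.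

Compound 3 stands highest of the three numbers in this assay, shown by a 2.6-fold higher number from compound 2 to compound 3 (0.41 log units; beyond the scatter) and by a 6.3-fold higher number from compound 1 to compound 3 (0.80 log units; beyond the scatter). Compound 4 `COc1ccc(-n2nc(C(=O)Nc3ccc(Oc4ccncc4-c4cccnc4)c(F)c3)c(=O)n(C)c2=O)c(OC)c1` differs from compound 3 by 2,4-dimethoxyphenyl in place of 3-chloro-4-fluorophenyl on an aromatic nitrogen. All three measured steps change the aryl on that same aromatic nitrogen: a 2.5-fold higher number from compound 1 to compound 2 (0.39 log units; beyond the scatter), a 6.3-fold higher number from compound 1 to compound 3 (0.80 log units; beyond the scatter) and a 2.6-fold higher number from compound 2 to compound 3 (0.41 log units; beyond the scatter), each of them modest, and none of them involves a methoxy-bearing aryl. Compound 4 is therefore expected to move only by a modest step from compound 3 in this assay, with the direction left open, estimated as a 2.0-fold lower number from compound 3 to compound 4 (0.31 log units; beyond the scatter). The estimate for compound 4 is 5000 nM, with a range from 1500 nM to 16000 nM.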

Compound 4, half-maximal inhibitory concentration: 2820 nM
Compound 4: the middle estimate sits 1.8-fold (0.25 log units) above what was measured, within the range that was stated.
By their numbers in this assay, from the lowest: compounds 1, 4 and 2 (each within the scatter of the next, the first and the last beyond it); then compound 3.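

In this assay the aromatic nitrogen also accepts an aryl without halogen: 2,4-dimethoxyphenyl gives a 3.6-fold lower number from compound 3 to compound 4 (0.55 log units; beyond the scatter) and remains level with the two other chlorinated aryls, with a 1.4-fold lower number from compound 2 to compound 4 (0.14 log units; within the scatter) and a 1.8-fold higher number from compound 1 to compound 4 (0.25 log units; within the scatter) both lying within the scatter. Among these four compounds, chlorine on the aryl is therefore not needed to reach the lower end of the numbers. The data give no explanation for these differences. From the compounds shown here alone, whether an amine or a carboxylic acid on this aryl, or a longer chain on the aromatic nitrogen, would keep these numbers stays open.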